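The source may report more compounds than this note shows. Statements on the series, on what has been measured and on what is new or still open speak of the compounds shown alone.

Measured compounds in an assay for inhibition of protein disulfide-isomerase (Homo sapiens), with a stated time of 1 h; on this read-out lower numbers stand for stronger inhibition and higher numbers for weaker inhibition:
- compound 1 `Cc1ccnc(NC(c2ccc(F)cc2)c2ccc3cccnc3c2O)c1`: 140 nM
- compound 2 `Cc1ccnc(NC(c2ccc3cccnc3c2O)c2c(F)cccc2Cl)c1`: > 40000 nM
- compound 3 `Cc1ccnc(NC(c2ccccc2)c2ccc3cccnc3c2O)c1`: < 200 nM

For compound 3 the result in this assay is a limit only, as the limit of < 200 nM in this assay, at which 1 of the 3 values shown sits, shows. For compound 2 the result is likewise a limit, as the limit of > 40000 nM in this assay, at which 1 of the 3 values shown sits, shows. Compound 1 gives a number in this assay.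

Compound 4 `Cc1ccnc(NC(c2cc(C)ccc2C)c2ccc3cccnc3c2O)c1` is not yet measured. The change from compound 3: 2,5-dimethylphenyl in place of phenyl on a saturated chain carbon bound to an aromatic carbon and a nitrogen on an aromatic ring. The measured steps at this same carbon are an at least 280-fold higher number from compound 1 to compound 2 (2.45 log units; beyond the scatter) and an at least 200-fold lower number from compound 2 to compound 3 (2.30 log units; beyond the scatter); both show that a substituted aryl group at this position can cost a great deal. The 2,5-dimethylphenyl group of compound 4 is a different substitution pattern, so a loss of similar kind, though probably smaller, is expected. Compound 4 is therefore estimated at 3000 nM (range 300 nM to 30000 nM), a weakening of an at least 15-fold higher number from compound 3 to compound 4 (1.17 log units; beyond the scatter) that is expected to exceed the scatter.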

Compound 4, half-maximal inhibitory concentration: > 40000 nM
Compound 4: no number, only a limit (the forecaster's own chance of this, stated with the estimate: 25%); middle value at least 13-fold (1.12 log units) from the limit.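

In this assay, 2,5-dimethylphenyl on this saturated chain carbon gives an at least 200-fold higher number from compound 3 to compound 4 (2.30 log units; beyond the scatter) and an at least 280-fold higher number from compound 1 to compound 4 (2.45 log units; beyond the scatter). The loss therefore does not need a halogen: both aryl groups here with two substituents, in compound 2 and compound 4, lose strongly, while the 4-fluorophenyl of compound 1 does not. Compound 4 gives a limit, not a number: the limit of > 40000 nM in this assay, at which 2 of the 4 values shown sit.

The step between compound 2 and compound 4 cannot be read, so the two aryl groups cannot be ranked. From the compounds shown here alone, whether a single methyl, a methoxy or an amine on the phenyl would keep the strength remains open.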